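Removing the Amino Group from a Chloromethyl Benzyl Purine

A few compounds are considered here, and "the series" means these few. Any claim that something is new, unique, unknown or untested is made for them only; others in the source may bear on it.

Compound 1 `Nc1nc(Cl)c2ncn(Cc3ccccc3CCl)c2n1`: > 100000 nM
Compound 2 `ClCc1cccc(Cn2cnc3nc(Cl)nc(Cl)c32)c1`: 45700 nM

In a functional assay on OVCAR-8 cells (Homo sapiens) for cytotoxicity, read by sulforhodamine B assay, with a stated time of 48 h (a lower number here means that less compound is tolerated, a higher number that more compound is tolerated), compound 1 gives > 100000 nM, a limit of the assay rather than a number. Compound 2 differs from compound 1 in more than one place; in this assay compound 2 gives 45700 nM. Compound 1 thus stands at the limit of > 100000 nM in this assay, at which 1 of the 2 values shown sits, so its position is known only as a limit. Compound 3 `ClCc1ccccc1Cn1cnc2c(Cl)ncnc21` differs from compound 1 by hydrogen in place of amino on an aromatic carbon. Among the compounds with values here, with no measured step of this kind, the change is expected to be an at least 1.2-fold lower number from compound 1 to compound 3 (0.09 log units; that floor lies within the scatter), within the scatter. Compound 3 is estimated at 80000 nM, between 25000 nM and 300000 nM.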

Compound 3, concentration lethal to 50% of the cells: 20400 nM
For compound 3 the middle estimate is 3.9-fold (0.59 log units) above the measured one; the measured number lies below the stated range.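

In this assay, within the data shown here, hydrogen in place of amino on the aromatic carbon between two ring nitrogen atoms gives an at least 4.9-fold lower number from compound 1 to compound 3 (0.69 log units; beyond the scatter), the first measured step at this position, and it lies beyond the scatter. Removing the amino group therefore does change the read-out here. The step gives only a floor on its size because the value of compound 1 is a limit of the assay and not a number: the limit of > 100000 nM in this assay, at which 1 of the 3 values shown sits.

Going by these compounds, how far the true step exceeds that floor remains open. So does how a methylamino or methoxy group on the same carbon would compare.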